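The compounds below may be only part of what the source reports. "The series", "measured", "known", "first", "only" and "open" are said of these compounds alone.

Compound 2 `CCC(C)(C)Cc1c[nH]c(CCc2ccc(-c3cnccn3)cc2)n1` gives the lowest number of the three in a functional assay on HEK293 cells for agonist activity at Bombesin receptor subtype-3 (Mus musculus), read by luminescence and calcium flux, with a stated time of 10 min (a higher number here means that more compound is needed for the effect, a lower number that less compound is needed), at 11 nM. Compound 1 `CCC(C)(C)Cc1c[nH]c(CCc2ccc(-c3cccc(C)n3)cc2)n1` gives 19 nM in this assay, and compound 3 `CCC(C)(C)Cc1c[nH]c(CCc2ccc(-c3cccc(C#N)n3)cc2)n1` gives 26 nM. The step of a 1.7-fold lower number from compound 1 to compound 2 (0.24 log units; within the scatter) and the step of a 1.4-fold higher number from compound 1 to compound 3 (0.14 log units; within the scatter) both stay within the scatter, while the step of a 2.4-fold higher number from compound 2 to compound 3 (0.37 log units; beyond the scatter) is a modest one beyond it, so among these three the spread is small.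

Compound 4 `CCC(C)(C)Cc1c[nH]c(CCc2ccc(N3CCCCC3)cc2)n1` differs from compound 2 in one place: piperidin-1-yl in place of pyrazin-2-yl on an aromatic carbon. All three measured steps exchange one six-membered aromatic ring with hetero atoms for another of the same kind, and none exchanges such a ring for a six-membered non-aromatic ring with one hetero atom or removes a hydrogen-bond acceptor as this change does. The measured steps therefore bear only loosely on it. Given that the closest exchange, a 2.4-fold higher number from compound 2 to compound 3 (0.37 log units; beyond the scatter), already raised the number, a step towards a higher number, of moderate size and beyond the scatter, is expected as a 5.5-fold higher number from compound 2 to compound 4 (0.74 log units; beyond the scatter). Compound 4 is accordingly estimated at 60 nM, with a range from 20 nM to 250 nM.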

Compound 4, half-maximal effective concentration: 28 nM
Compound 4: middle estimate off by 2.1-fold (0.33 log units), on the high side, and the stated range covers the measured number.
By their numbers in this assay, from the lowest: compounds 2, 1, 3 and 4 (each within the scatter of the next, the first and the last beyond it).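

In this assay, an aromatic ring is not required on this aromatic carbon para to a large group: piperidin-1-yl, a six-membered non-aromatic ring, in place of pyrazin-2-yl gives a 2.5-fold higher number from compound 2 to compound 4 (0.41 log units; beyond the scatter) as a modest step. Against the two substituted pyridine groups the same kind of exchange shows no separation, with a 1.1-fold higher number from compound 3 to compound 4 (0.03 log units; within the scatter) and a 1.5-fold higher number from compound 1 to compound 4 (0.17 log units; within the scatter) as the readings, so only the comparison with compound 2 shows a difference from compound 4. Nothing available gives a reason for the step from pyrazin-2-yl to piperidin-1-yl.

On these data alone, what remains open is whether the ring nitrogen of piperidin-1-yl matters at this position, which cyclohexyl or morpholin-4-yl could test. An open-chain amine such as diethylamino would show whether a ring is needed here at all.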